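The source may hold more compounds than are shown below. What is called first, only, known or untested is meant among the compounds shown, and "the series" means these compounds.

Measured so far:
compound 1, `Cc1c(C=O)cc(-c2ccc(S(C)(=O)=O)cc2)n1-c1cccc(F)c1`, 39% in a functional assay on the whole organism (strain Swiss albino) for inhibition, with Mus musculus as the target, in the writhing test, with a stated time of 30 min, at a dose of 10 mg/kg by the oral route; on this read-out higher numbers stand for a stronger effect at the one dose given and lower numbers for a weaker effect
compound 2, `Cc1c(C=O)cc(-c2ccc(S(C)(=O)=O)cc2)n1-c1ccc(F)c(F)c1`, 53% in this assay
compound 3, `Cc1c(C#N)cc(-c2ccc(S(C)(=O)=O)cc2)n1-c1cccc(F)c1`, 28% in this assay

Compound 4, `Cc1c(C#N)cc(-c2ccc(S(C)(=O)=O)cc2)n1-c1ccc(F)c(F)c1`, is not yet measured. It differs from compound 3 by fluoro in place of hydrogen on an aromatic carbon. The same change is already measured once in this series, as fluoro in place of hydrogen on an aromatic carbon, where it gave a number 14 percentage points higher from compound 1 to compound 2 (beyond the scatter). The two cores differ by cyano in place of formyl on an aromatic carbon, which gave a number 11 percentage points lower from compound 1 to compound 3 (beyond the scatter) and leaves compound 3 lowest of the three. The place of the change reads the same word for word in both pairs, so it is taken as the same change. Among the compounds with values here, for compound 4 a step of a number 12 percentage points higher from compound 3 to compound 4 (beyond the scatter) in this assay is expected, resting on the single earlier step of a number 14 percentage points higher from compound 1 to compound 2 (beyond the scatter) and carrying the uncertainty of one example. Compound 4 is therefore estimated at 40%, between 28% and 54%.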

Compound 4, a percentage reported as inhibition, in the whole organism at one dose (the size of the read-out at that dose, not a potency): 19%
Compound 4: middle estimate off by 21 percentage points, on the high side; measured number below the stated range.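

In this assay, the change from 3-fluorophenyl to 3,4-difluorophenyl on the core of compound 3 gives a number 9 percentage points lower from compound 3 to compound 4 (within the scatter), which does not match the step on the core of compound 1: the same change on two cores in this assay, a number 14 percentage points higher (beyond the scatter) from compound 1 to compound 2 and a number 9 percentage points lower (within the scatter) from compound 3 to compound 4, 23 percentage points apart, beyond the scatter of two such steps. The exchange of formyl for cyano also depends on the partner group, giving a number 34 percentage points lower from compound 2 to compound 4 (beyond the scatter), a larger drop than with 3-fluorophenyl: the same change on two cores in this assay, a number 11 percentage points lower (beyond the scatter) from compound 1 to compound 3 and a number 34 percentage points lower (beyond the scatter) from compound 2 to compound 4, 23 percentage points apart, beyond the scatter of two such steps. Neither change therefore carries over as a fixed increment within these four compounds, although a single pair of steps for each change does not show why, nor how either change behaves on other cores.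

Going by these compounds, whether this dependence holds for other groups in place of formyl or cyano, such as a carboxylic acid or an amide, remains open. The same applies to a chloro or methoxy group in place of the added fluoro.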